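The source may report more compounds than this note shows. Statements on the series, on what has been measured and on what is new or still open speak of the compounds shown alone.

Working notes on the series. Going by the values given here, in a functional assay on T47D cells (Homo sapiens) for inhibition, read by CCK-8 assay, with a stated time of 72 h, tested at 1 uM (on this read-out higher numbers stand for more inhibition of growth at the one concentration tested and lower numbers for less inhibition of growth), compound 1 (`CN(C)C(=O)c1cc2cnc(Nc3ccc(NC(=O)C4(C(=O)Nc5ccc(Cl)c(C(F)(F)F)c5)CC4)cc3)nc2n1C1CCCC1`) gives 6.9% and compound 2 (`COc1cccc(NC(=O)C2(C(=O)Nc3ccc(Nc4ncc5cc(C(=O)N(C)C)n(C6CCCC6)c5n4)cc3)CC2)c1`) gives 56.3% as the higher of the two numbers so far. Next is compound 3 (`CN(C)C(=O)c1cc2cnc(Nc3ccc(NC(=O)C4(C(=O)Nc5ccccc5)CC4)cc3)nc2n1C1CCCC1`), which keeps the core of compound 2 and changes only its aryl group: hydrogen in place of methoxy on an aromatic carbon leaves phenyl, with hydrogen in place of methoxy on an aromatic carbon. Among the compounds with values here, one measured step bears on this, a number 49.4 percentage points higher from compound 1 to compound 2 (beyond the scatter) with 3-methoxyphenyl in place of 4-chloro-3-(trifluoromethyl)phenyl on an amide-type nitrogen. That step is large and beyond the scatter, but it exchanges a different pair of groups, and no measurement isolates the methoxy alone. Compound 3 carries neither the 3-methoxyphenyl of compound 2 nor the 4-chloro-3-(trifluoromethyl)phenyl of compound 1, so a number within the span of the two is expected, anchored on compound 2 at 56.3% as the closer structure. The expected change is small to moderate and downward, an estimated a number 12.3 percentage points lower from compound 2 to compound 3 (beyond the scatter) in this assay and well short of the large step described above. For compound 3 the estimate is 44% (expected range 20% to 68%).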

Compound 3, percent growth inhibition at one concentration: 52.8%
Compound 3: the middle estimate sits 8.8 percentage points below what was measured; low and high end bracket the measured number.
By their numbers in this assay, from the lowest: compound 1; then compounds 3 and 2 (each within the scatter of the next).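

In this assay, hydrogen in place of methoxy on an aromatic carbon, meta to a large group, gives a number 3.5 percentage points lower from compound 2 to compound 3 (within the scatter), so for this pair the methoxy makes no difference that the read-out can separate from the scatter. Phenyl in place of 4-chloro-3-(trifluoromethyl)phenyl on the amide-type nitrogen gives a number 45.9 percentage points higher from compound 1 to compound 3 (beyond the scatter), a large step with no methoxy involved, which ties the low number of compound 1 to the presence of the 4-chloro-3-(trifluoromethyl)phenyl group rather than to the absence of the methoxy in that compound. No measurement at hand gives a reason for either step.

The compounds shown leave open how the chloro and trifluoromethyl parts of that group each contribute to the large step, and whether either part alone on the phenyl would give a number near that of compound 1 or near that of compound 3. They also leave open whether an amine or a carboxylic acid at the methoxy position would be tolerated in the same way.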